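Methyl on the ring nitrogen's phenyl: expected small effect

The source may hold more compounds than are shown below. What is called first, only, known or untested is meant among the compounds shown, and "the series" means these compounds.

Of the compounds shown here, three sharing one core have been measured in a functional assay on HT-29 cells (Homo sapiens) for cytotoxicity, read by MTT assay, with a stated time of 72 h; a higher number here means a weaker inhibitor, a lower number a stronger inhibitor. Compound 1 `O=C1CS/C(=N\c2csc(-c3ccc(Cl)cc3)c2)N1` carries a hydrogen on the amide-type nitrogen in the ring and gives 17100 nM. Compound 2 `O=C1CS/C(=N\c2csc(-c3ccc(Cl)cc3)c2)N1c1ccc(Cl)cc1` carries a 4-chlorophenyl there and gives 36600 nM; compound 3 `O=C1CS/C(=N\c2csc(-c3ccc(Cl)cc3)c2)N1c1ccccc1` carries a phenyl and gives 41400 nM. Placing a ring on that nitrogen raised the number modestly, by a 2.1-fold higher number from compound 1 to compound 2 (0.33 log units; beyond the scatter) and a 2.4-fold higher number from compound 1 to compound 3 (0.38 log units; beyond the scatter), both beyond the scatter. Among the three, compound 3 has the highest number, but the difference is small: a 1.1-fold higher number from compound 2 to compound 3 (0.05 log units; within the scatter), within the scatter, so compound 2 and compound 3 cannot be ordered.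

Compound 4 `Cc1ccc(N2C(=O)CS/C2=N\c2csc(-c3ccc(Cl)cc3)c2)cc1` differs from compound 3 by methyl in place of hydrogen on an aromatic carbon, para to a large group. Among the compounds with values here, the step that bears on this is the one from compound 2 to compound 3, where chloro and hydrogen at that same position gave a 1.1-fold higher number from compound 2 to compound 3 (0.05 log units; within the scatter). A substituent at this position of the phenyl thus made no difference beyond the scatter, and a methyl is expected to behave alike. For this assay, compound 4 is estimated to show no step beyond the scatter, a 1.0-fold lower number from compound 3 to compound 4 (0.01 log units; within the scatter). Compound 4 is therefore expected at about 40000 nM, within a range from 15000 nM to 100000 nM.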

Compound 4, half-maximal inhibitory concentration: 28900 nM
For compound 4 the middle estimate is 1.4-fold (0.14 log units) above the measured one, and the stated range covers the measured number.
By their numbers in this assay, from the lowest: compounds 1, 4, 2 and 3 (each within the scatter of the next, the first and the last beyond it).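

In this assay, the phenyl on the ring nitrogen now carries three different groups para to a large group (hydrogen, chloro and methyl), and none of them can be told apart: a 1.4-fold lower number from compound 3 to compound 4 (0.16 log units; within the scatter) and a 1.3-fold lower number from compound 2 to compound 4 (0.10 log units; within the scatter) both stay within the scatter, so the earlier result for chloro and hydrogen extends to a third group and to the direct comparison of methyl with chloro. The new compound also adds a caution about the ring on that nitrogen, since the step to 4-methylphenyl, a 1.7-fold higher number from compound 1 to compound 4 (0.23 log units; within the scatter), lies within the scatter, whereas the step to phenyl, a 2.4-fold higher number from compound 1 to compound 3 (0.38 log units; beyond the scatter), lies just beyond it, so these modest steps give no firm sign that every such ring raises the number. Nothing shown here offers an explanation for these small steps.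

Going by these compounds, it remains open whether a quite different group at this same place on the phenyl, such as an amine, a carboxylic acid or a longer chain like butyl, would produce a step beyond the scatter. The compounds shown also leave open whether hydrogen, chloro and methyl would stay this close in any test other than this assay.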